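A few compounds are considered here, and "the series" means these few. Any claim that something is new, unique, unknown or untested is made for them only; others in the source may bear on it.

Compound 1 `Nc1nc2c(c(-c3ccccc3)cn2[C@@H]2O[C@H](CO)[C@@H](O)[C@H]2O)c(=O)[nH]1`: > 20000 nM in a functional assay on HepG2 cells (Homo sapiens) for antiproliferative activity, read by XTT assay, with a stated time of 72 h; on this read-out lower numbers stand for stronger inhibition and higher numbers for weaker inhibition.
Compound 2 `O=c1[nH]cnc2c1c(-c1cc3ccccc3o1)cn2[C@@H]1O[C@H](CO)[C@@H](O)[C@H]1O`: > 20000 nM in this assay.

Compound 2 gives only a limit of this assay, not a number. Both values shown sit at that same limit (the limit of > 20000 nM in this assay, at which 2 of the 2 values shown sit), so no ordering between the two compounds can be read. Compound 3 `O=c1[nH]cnc2c1c(-c1ccco1)cn2[C@@H]1O[C@H](CO)[C@@H](O)[C@H]1O` differs from compound 2 in one place: furan-2-yl in place of 1-benzofuran-2-yl on an aromatic carbon. Among the measured compounds shown here, no step between measured compounds is available to guide the size of this change, so in this assay I expect no shift beyond the usual scatter, and most likely another limit. For compound 3 the estimate in this assay is 30000 nM with a range from 15000 nM to 80000 nM, an expected step that the limit leaves unreadable from compound 2 to compound 3.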

Compound 3, half-maximal inhibitory concentration: > 15000 nM
Compound 3 was reported as a limit; the forecaster's own chance of this, stated with the estimate: 85%; the middle value does not contradict the limit.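

Among the compounds shown here, compound 2 and compound 3 are both reported only as limits in this assay, so no step between them can be read. Going by these compounds, whether furan-2-yl and 1-benzofuran-2-yl differ at all in this read-out stays open.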